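The source may report more compounds than this note shows. Statements on the series, on what has been measured and on what is new or still open speak of the compounds shown alone.

Measured compounds:
compound 1 `COc1ccc(/C=C/c2cc(OC)cc(OC)c2/C=C/C(=O)c2cc3cc(OC)ccc3oc2=O)cc1` — > 60000 nM
compound 2 `COc1ccc(/C=C/c2cc(OC)cc(OC)c2/C=C/C(=O)c2cc3cc(Br)cc(OC)c3oc2=O)cc1` — > 60000 nM
compound 3 `CCOc1ccc2cc(C(=O)/C=C/c3c(/C=C/c4ccc(OC)cc4)cc(OC)cc3OC)c(=O)oc2c1` — 7070 nM

In an assay on isolated protein for inhibition of Amine oxidase [flavin-containing] A (Homo sapiens), read by fluorescence, with a stated time of 15 min (a higher number here means a weaker inhibitor, a lower number a stronger inhibitor), compound 1 gives > 60000 nM, which is a limit of the assay and not a number. Compound 2 likewise gives only the limit > 60000 nM in this assay. Going by the values given here, compound 3 is the one compound of the three with a number, 7070 nM in this assay. The two further values are a limit, so no ordering among the three can be stated beyond that (the limit of > 60000 nM in this assay, at which 2 of the 3 values shown sit).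

Compound 4 `COc1ccc(/C=C/c2cc(OC)cc(OC)c2/C=C/C(=O)c2cc3ccc(Cl)cc3oc2=O)cc1` has not been measured. It differs from compound 3 by chloro in place of ethoxy on an aromatic carbon. Among the compounds with values here, no step between two measured compounds is available as a guide, so the size of the change can only be guessed. With two of three members sitting at the limit and only compound 3 giving a number, the expectation for compound 4 is a step toward weaker inhibition from compound 3 to compound 4 of a 2.8-fold higher number from compound 3 to compound 4 (0.45 log units; beyond the scatter), beyond the scatter but not certain. Compound 4 is therefore estimated at 20000 nM in this assay, within a range of 6000 nM to 60000 nM, with a fair chance that only a limit is reported.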

Compound 4, half-maximal inhibitory concentration: > 60000 nM
Compound 4 was reported as a limit; the forecaster's own chance of this, stated with the estimate: 40%; middle value at least 3.0-fold (0.47 log units) from the limit.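

Going by these compounds alone, replacing ethoxy with chloro on this aromatic carbon, para to a fused ring, gives the first step that can be read in this assay: an at least 8.4-fold higher number from compound 3 to compound 4 (0.92 log units; beyond the scatter). Compound 4 gives > 60000 nM, which is a limit of the assay and not a number. Ethoxy is thus the only group at this place shown to go with a number, chloro does not keep that number, and the step can be read only as a minimum size: the limit of > 60000 nM in this assay, at which 3 of the 4 values shown sit.

With chloro as the sole comparison, the shown compounds do not separate the role of the ethoxy oxygen from that of its two carbons, and a methoxy, a propoxy, a hydroxyl or a plain ethyl at this place would be needed to tell these apart. From the compounds shown here alone, compound 1 and compound 2 differ from compound 3 in more than one place, so they give no clean reading of this position, and how far compound 4 and these two lie beyond the limit stays unknown.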